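Sulfur substituent swap from compound 1 to compound 4

The compounds below may be only part of what the source reports. "The series", "measured", "known", "first", "only" and "open" are said of these compounds alone.

- compound 1 `C#CCSc1nc(Sc2nnnn2CCN(C)C)c(C#N)c(-c2ccc(Cl)cc2)n1`: 5300 nM
- compound 2 `C#CCSc1nc(Sc2ccccn2)c(C#N)c(-c2cc(OC)c(OC)c(OC)c2)n1`: > 20000 nM, a limit
- compound 3 `C#CCSc1nc(Sc2nc3ccccc3s2)c(C#N)c(-c2cc(OC)c(OC)c(OC)c2)n1`: > 20000 nM, a limit

Among the measured compounds shown here, in a functional assay on PC-9 cells (Homo sapiens) for antiproliferative activity, read by MTT assay (on this read-out higher numbers stand for weaker inhibition and lower numbers for stronger inhibition), compound 1 holds the only actual number, and the other entries sit at the limit of > 20000 nM in this assay, at which 2 of the 3 values shown sit.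

Compound 4 `C#CCSc1nc(Sc2nccs2)c(C#N)c(-c2ccc(Cl)cc2)n1` has 1,3-thiazol-2-yl in place of 1-(2-(dimethylamino)ethyl)-1H-tetrazol-5-yl on a sulfur.

For the measured compounds named here, the one measured swap on such a sulfur is a step that the two limits leave unreadable from compound 2 to compound 3, and it sets no size for this change. Compound 3, with 1,3-benzothiazol-2-yl on that sulfur, has > 20000 nM, which is a limit, and this only weakly favours weaker inhibition, since compound 3 also differs from compound 1 elsewhere.

The expected step is a 1.7-fold higher number from compound 1 to compound 4 (0.23 log units; within the scatter), towards weaker inhibition. For compound 4 the estimated value is 9000 nM, with an expected range of 3000 nM to 25000 nM.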

Compound 4, half-maximal inhibitory concentration: 4130 nM
Estimate against measurement, compound 4: 2.2-fold (0.34 log units) above, and the stated range covers the measured number.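

In this assay, this sulfur position now has its first readable step: a 1.3-fold lower number from compound 1 to compound 4 (0.11 log units; within the scatter). On the core of compound 1, the 10-heavy-atom 1-(2-(dimethylamino)ethyl)-1H-tetrazol-5-yl and the 5-heavy-atom 1,3-thiazol-2-yl therefore stand within the scatter of each other, so this pair shows no need for the dimethylaminoethyl chain.

From the compounds shown here alone, whether a carboxylic acid or a primary amine on the thiazole would shift the number stays open. Compound 2 and compound 3 give only limits, so they set no size for other groups on this sulfur: the limit of > 20000 nM in this assay, at which 2 of the 4 values shown sit.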